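The source may hold more compounds than are shown below. What is called first, only, known or untested is meant among the compounds shown, and "the series" means these compounds.

Measured so far:
Compound 1 `O=C(O)CCCCCC[C@@H]1[C@@H](CC[C@@H](O)CCc2ccc(F)cc2)[C@H](O)C[C@@H]1O` gives 210 nM in an in vitro assay on CHO-KI cells for displacement of a labelled ligand from prostaglandin F2-alpha receptor (Homo sapiens); a higher number here means a weaker inhibitor, a lower number a stronger inhibitor.
Compound 2 `Cc1ccc(CC[C@H](O)CC[C@@H]2[C@@H](CCCCCCC(=O)O)[C@@H](O)C[C@H]2O)cc1` gives 4400 nM in this assay.

Within the data shown here, compound 2 holds the higher number of the two; the only step among them, a 21-fold higher number from compound 1 to compound 2 (1.32 log units; beyond the scatter), separates it from compound 1. Compound 3 `CCc1cccc(CC[C@H](O)CC[C@@H]2[C@@H](CCCCCCC(=O)O)[C@@H](O)C[C@H]2O)c1` differs from compound 2 by 3-ethylphenyl in place of 4-methylphenyl on a saturated chain carbon, three bonds along the chain from an oxygen on a saturated carbon. Among the measured compounds shown here, no measured pair covers this change; the single step on the same ring shows that exchanging the aromatic substituent can move the number greatly, and nothing here fixes the direction. A step of modest size, a 1.3-fold lower number from compound 2 to compound 3 (0.10 log units; within the scatter), is therefore expected, with wide uncertainty. For compound 3 the estimate is 3500 nM, range 900 nM to 14000 nM.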

Compound 3, half-maximal inhibitory concentration: 540 nM
For compound 3 the middle estimate is 6.5-fold (0.81 log units) above the measured one; measured number below the stated range.
By their numbers in this assay, from the lowest: compound 1; then compound 3; then compound 2.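

In this assay, 3-ethylphenyl in place of 4-methylphenyl gives an 8.1-fold lower number from compound 2 to compound 3 (0.91 log units; beyond the scatter), so a carbon substituent on this ring need not bring the high number of compound 2. The 4-fluorophenyl group still holds the lowest number of the three: 3-ethylphenyl in its place gives a 2.6-fold higher number from compound 1 to compound 3 (0.41 log units; beyond the scatter). Substituent and ring position change together in these steps, and their shares cannot be separated. A 3-methylphenyl or 4-ethylphenyl group would divide them, and a 3-fluorophenyl group would test the fluoro substituent at the other ring position. No measurement on hand gives a reason for either step.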